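Moving the fluorine once more around the phenyl ring

The source may report more compounds than this note shows. Statements on the series, on what has been measured and on what is new or still open speak of the compounds shown alone.

In a functional assay on A549 cells (Homo sapiens) (on this read-out higher numbers stand for an effect only at larger amounts of compound and lower numbers for an effect already at smaller amounts), compound 3 `COc1cc2nc(-c3cccc(F)c3)nc(O)c2cc1OC` gives > 20 ug/mL as its reading, which is a limit. Compound 2 `COc1cc2nc(-c3ccccc3F)nc(O)c2cc1OC` gives < 5 ug/mL as its reading, also a limit. Putting 3-fluorophenyl in place of 2-fluorophenyl produced an at least 4.0-fold higher number from compound 2 to compound 3 (0.60 log units; beyond the scatter) and this lies beyond the scatter, so the fluorine's position can matter on this core. Compound 4 `COc1cc2nc(-c3ccc(F)cc3)nc(O)c2cc1OC` carries 4-fluorophenyl in place of 3-fluorophenyl on an aromatic carbon on the same core. Compound 1 `Oc1nc(-c2ccc(F)cc2)nc2ccccc12` carries 4-fluorophenyl on another core and gives 7.5 ug/mL as a true number. Within the data shown here, that single value is the only guide, so the expectation is loose. The estimate is an at least 2.0-fold lower number from compound 3 to compound 4 (0.30 log units; that floor lies within the scatter) in this assay toward smaller numbers. Compound 4 is expected near 10 ug/mL within a range from 4 ug/mL to 25 ug/mL as an estimate.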

Compound 4, concentration for half-maximal effect: > 20 ug/mL
Compound 4 ended at the assay's limit (the forecaster's own chance of this, stated with the estimate: 35%); middle value at least 2.0-fold (0.30 log units) away from the limit.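

On the shared core, 4-fluorophenyl in place of 2-fluorophenyl gives an at least 4.0-fold higher number from compound 2 to compound 4 (0.60 log units; beyond the scatter), so 2-fluorophenyl now stands apart from both other fluorophenyl groups in this assay, not from 3-fluorophenyl alone. The step from compound 3 to compound 4 cannot be read because both readings are limits: the limit of > 20 ug/mL in this assay, at which 2 of the 4 values shown sit.

As far as these compounds go, the true values behind the limits of compound 2, compound 3 and compound 4 remain open. From the compounds shown here alone, it is also open how the reading would change with an amine or a carboxylic acid in place of the fluorine of 2-fluorophenyl.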